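The compounds below may be only part of what the source reports. "The series", "measured", "known", "first", "only" and "open" are said of these compounds alone.

Compound 1 `CC(C)(C)OC(=O)N1CCC(Oc2ncnc3c2CCN3c2ccc(S(C)(=O)=O)cc2F)CC1` and compound 2 `CCCOC(=O)N1CCC(Oc2ncnc3c2CCN3c2ccc(S(C)(=O)=O)cc2F)CC1` share one core and differ only at the ester end of the carbamate. In a functional assay on CHO-K1 cells with Glucose-dependent insulinotropic receptor (Homo sapiens) as the target, read by a luciferase reporter, with a stated time of 5 h (a higher number here means a larger maximal response, a lower number a smaller maximal response), compound 1 gives 139%, while compound 2 gives 111%, which leaves compound 2 with the lower of the two numbers; this step was a number 28 percentage points lower from compound 1 to compound 2 (beyond the scatter). Compound 3 `CCCCOC(=O)N1CCC(Oc2ncnc3c2CCN3c2ccc(S(C)(=O)=O)cc2F)CC1` carries methyl in place of hydrogen on a saturated chain carbon, three bonds along the chain from an oxygen next to a carbonyl group. Among the compounds with values here, no measured step covers this change, and the single step from compound 1 to compound 2 only shows that the ester group does matter. Compound 3 is therefore expected to stay near compound 2, with a step of a number 4 percentage points higher from compound 2 to compound 3 (within the scatter) within the scatter, at an estimated 115% ranging from 90% to 140%.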

Compound 3, largest response reached (reported as percent of maximum), in percent of the reference or control that the assay uses: 131%
Estimate against measurement, compound 3: 16 percentage points below, and the stated range covers the measured number.
By their numbers in this assay, from the lowest: compound 2; then compounds 3 and 1 (each within the scatter of the next).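

The added methyl is not silent at this position: propyl to butyl gives a number 20 percentage points higher from compound 2 to compound 3 (beyond the scatter) and so leaves compound 2 alone at the low end of the three. Butyl in place of tert-butyl gives a number 8 percentage points lower from compound 1 to compound 3 (within the scatter) and so does not separate the two esters in this read-out. No evidence at hand accounts for this response to one added carbon. From the compounds shown here alone, whether a longer chain such as pentyl would hold the response, or a terminal amine or carboxylic acid on the butyl chain would alter it, remains open.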